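The source may hold more compounds than are shown below. What is called first, only, known or untested is meant among the compounds shown, and "the series" means these compounds.

Compounds measured:
- compound 1, `CCCCc1cc(Cn2c(CC)nc3c(C)cc(C)nc32)ccc1OC(C(=O)O)c1ccccc1`: 140 nM
- compound 2, `C=CCc1cc(Cn2c(CC)nc3c(C)cc(C)nc32)ccc1OC(C(=O)O)c1ccccc1`: 270 nM
- compound 3, `CCc1nc2c(C)cc(C)nc2n1Cc1ccc(OC(C(=O)O)c2ccccc2)c(C(C)C)c1`: 3300 nM

All three numbers come from an assay on Midbrain with Type-2 angiotensin II receptor (Rattus norvegicus) as the target; a lower number here means a stronger inhibitor, a higher number a weaker inhibitor. Compound 3 stands at the high end of the set: the step of a 24-fold higher number from compound 1 to compound 3 (1.37 log units; beyond the scatter) and the step of a 12-fold higher number from compound 2 to compound 3 (1.09 log units; beyond the scatter) both lie beyond the scatter, whereas the step of a 1.9-fold higher number from compound 1 to compound 2 (0.29 log units; within the scatter) lies within it. Compound 3 is thus the weakest inhibitor of the three in this assay.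

Compound 4, `CCc1nc2c(C)cc(C)nc2n1Cc1ccc(OC(C(=O)O)c2ccccc2)c(C(=O)c2ccccc2)c1`, has not been measured. It differs from compound 3 in one place: benzoyl in place of isopropyl on an aromatic carbon, on an aromatic carbon of a six-membered aromatic ring of carbon only, ortho to a carboxy(phenyl)methoxy group and meta to a large group.

Bearing on this step are only the two steps that end at compound 3, a 24-fold higher number from compound 1 to compound 3 (1.37 log units; beyond the scatter) and a 12-fold higher number from compound 2 to compound 3 (1.09 log units; beyond the scatter), both large. They show that the isopropyl at this place sits far above the butyl and allyl of compound 1 and compound 2. No measured step involves a benzoyl, so the direction of leaving the isopropyl for a benzoyl is not shown directly. The expectation is a moderate recovery, giving an expected step of a 2.8-fold lower number from compound 3 to compound 4 (0.44 log units; beyond the scatter) in this assay, with wide uncertainty.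

Compound 4 is therefore estimated at 1200 nM, within a range of 250 nM to 6000 nM.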

Compound 4, half-maximal inhibitory concentration: 60 nM
The estimate for compound 4 lay 20-fold (1.30 log units) above the measured number; the measured number lies below the stated range.
By their numbers in this assay, from the lowest: compound 4; then compounds 1 and 2 (each within the scatter of the next); then compound 3.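

In this assay, the place ortho to a carboxy(phenyl)methoxy group accepts a benzoyl, and the change from isopropyl is large (a 55-fold lower number from compound 3 to compound 4 (1.74 log units; beyond the scatter)). Strong inhibition at this place is therefore not limited to the butyl and allyl chains: the benzoyl also gives a modest gain over each of them (a 4.5-fold lower number from compound 2 to compound 4 (0.65 log units; beyond the scatter); a 2.3-fold lower number from compound 1 to compound 4 (0.37 log units; beyond the scatter)), making compound 4 the strongest inhibitor of the four. The isopropyl of compound 3 now stands as the single poor group among those shown at this place, while a group with a ring and a carbonyl gives the lowest number, and no measurement is available that would explain this result.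

The compounds shown leave open which part of the benzoyl carries the gain, since an acetyl and a phenyl at the same place would separate the carbonyl from the ring. They also leave open how far the place tolerates further growth, as a benzoyl bearing a methoxy or a fluorine on its ring, or a phenylacetyl, would test, and whether a tert-butyl would fall as far as the isopropyl does.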